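Branching the Chain on the Amide-Type Nitrogen Side

A few compounds are considered here, and "the series" means these few. Any claim that something is new, unique, unknown or untested is made for them only; others in the source may bear on it.

The series rests on the core of compound 1 `CN1CCC(N2CCN(C(=O)c3nc4ccccc4n3Cc3ccccc3)CC2)CC1`. In a functional assay on CHO cells for antagonist activity at B1 bradykinin receptor (Macaca fascicularis), read by FLIPR and calcium flux (on this read-out lower numbers stand for stronger inhibition and higher numbers for weaker inhibition), compound 1 reaches only a limit of the assay rather than a number, > 5000 nM, which is the limit of > 5000 nM in this assay, at which 1 of the 3 values shown sits. Compound 2 `CN1CCC(N2CCN(C(=O)CN(C)C(=O)c3nc4ccccc4n3Cc3ccccc3)CC2)CC1` does give a number: in this assay compound 2 gives 268 nM. Compound 3 `CCN(CC(=O)N1CCN(C2CCN(C)CC2)CC1)C(=O)c1nc2ccccc2n1Cc1ccccc1` goes further, and in this assay compound 3 gives 16 nM. Of the two numbers recorded, compound 3 stands lowest, and the step of a 17-fold lower number from compound 2 to compound 3 (1.22 log units; beyond the scatter) lies beyond the scatter.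

Compound 4 `CC(C)N(CC(=O)N1CCN(C2CCN(C)CC2)CC1)C(=O)c1nc2ccccc2n1Cc1ccccc1` has not yet been measured. It differs from compound 3 by methyl in place of hydrogen on a saturated chain carbon bound to an amide-type nitrogen and a saturated chain carbon. Going by the values given here, the one measured step that bears on this change is a 17-fold lower number from compound 2 to compound 3 (1.22 log units; beyond the scatter), which was large; that step lengthened a chain, whereas the present change turns the chain into a branch, and no branch has been measured in this set. Continuing the same direction would lower the number again, but a branch need not follow a chain. Compound 4 is therefore expected to sit close to compound 3 or somewhat lower, a step of a 1.6-fold lower number from compound 3 to compound 4 (0.20 log units; within the scatter). The estimate for compound 4 in this assay is 10 nM, within a range from 3 nM to 40 nM.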

Compound 4, half-maximal inhibitory concentration: 465 nM
For compound 4 the middle estimate is 47-fold (1.67 log units) below the measured one; the whole stated range lies below it.
By their numbers in this assay, from the lowest: compound 3; then compounds 2 and 4 (each within the scatter of the next). At a limit, above all of these: compound 1.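

On the amide-type nitrogen, the number in this assay does not follow the size of the alkyl group in one direction: the change from ethyl to isopropyl, a single added methyl on a saturated chain carbon, gives a 29-fold higher number from compound 3 to compound 4 (1.46 log units; beyond the scatter) and removes the advantage that ethyl held over methyl. Going by these compounds alone, the comparison of the two outer members reads a 1.7-fold higher number from compound 2 to compound 4 (0.24 log units; within the scatter) and so does not separate isopropyl from methyl at this nitrogen, which leaves ethyl as the only one of the three groups that stands apart, and shows that branching at this carbon does not continue the trend from methyl to ethyl. The values shown give no reason for this reversal.

The compounds shown leave open whether the low number belongs to ethyl alone or would also hold for a straight propyl chain, a longer chain such as butyl, or a cyclopropyl group on the same nitrogen. They also leave open whether the loss follows branching at this carbon in general, which a group such as isobutyl, branched further out along the chain, or a tert-butyl group could help to settle.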